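From Bromo to Methoxy on a Shared Core

The source may report more compounds than this note shows. Statements on the series, on what has been measured and on what is new or still open speak of the compounds shown alone.

Compound 1 `O=C(/C=C/c1csc2ccccc12)c1cc(F)ccc1O`: 7100 nM
Compound 2 `O=C(/C=C/c1csc2ccccc12)c1cc(Br)ccc1O`: 660 nM

Going by the values given here, in a functional assay on A549 cells (Homo sapiens) for antiproliferative activity, read by sulforhodamine B assay, with a stated time of 72 h (on this read-out higher numbers stand for weaker inhibition and lower numbers for stronger inhibition), compound 2 gives 660 nM, the lower of the two numbers so far, while compound 1 gives 7100 nM. The next structure is compound 3 `COc1ccc(O)c(C(=O)/C=C/c2csc3ccccc23)c1`, which differs from compound 2 as follows: methoxy in place of bromo on an aromatic carbon. This is methoxy in place of bromo on an aromatic carbon, para to a hydroxy group. Among the compounds with values here, one measured step bears on it: an 11-fold lower number from compound 1 to compound 2 (1.03 log units; beyond the scatter), a large step beyond the scatter, with bromo in place of fluoro at that same carbon. Within the data shown here, it shows that the group there can move the number strongly, but no methoxy compound has yet been measured. A moderate step toward a higher number in this assay is therefore expected, smaller than the measured one. The expected step is a 3.0-fold higher number from compound 2 to compound 3 (0.48 log units; beyond the scatter). For compound 3 the estimated value is 2000 nM, with an expected range of 600 nM to 7000 nM.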

Compound 3, half-maximal inhibitory concentration: 580 nM
Beside the measured number, compound 3's estimate is 3.4-fold (0.54 log units) above it; the whole stated range lies above it.
By their numbers in this assay, from the lowest: compounds 3 and 2 (each within the scatter of the next); then compound 1.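

In this assay, methoxy in place of bromo, para to a hydroxy group, gives a 1.1-fold lower number from compound 2 to compound 3 (0.06 log units; within the scatter) at this carbon, so the assay does not separate these two groups. Methoxy in place of fluoro gives a 12-fold lower number from compound 1 to compound 3 (1.09 log units; beyond the scatter) on the shared core, which shows that the large step seen earlier is not confined to bromo, and that of the three groups shown, only fluoro stands apart. No measurement shown here accounts for this result.

The compounds shown leave open whether an amine, a carboxylic acid or a longer chain such as ethoxy at this carbon would stay level with compound 2 and compound 3 or move toward compound 1. They also leave open whether a hydroxy group or a methyl group here would do the same.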